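Replacing trifluoromethyl by fluoro on a pyrazine hydrazone

The source may hold more compounds than are shown below. What is called first, only, known or untested is meant among the compounds shown, and "the series" means these compounds.

Measured compounds:
Compound 1, `O=C(N/N=C/c1ccccc1)c1cnccn1`: 21.7%
Compound 2, `CC(C)c1ccc(/C=N/NC(=O)c2cnccn2)cc1`: 19.4%
Compound 3, `O=C(N/N=C/c1ccc(C(F)(F)F)cc1)c1cnccn1`: 0%

In a functional assay on the whole organism (strain Swiss) for inhibition, with Mus musculus as the target, with stated times of 40 min and 6 h, at a dose of 100 mg/kg by the oral route (on this read-out higher numbers stand for more inhibition at the one dose given (going by the name of the read-out) and lower numbers for less inhibition), compound 3 stands lowest of the three measured compounds. Compound 2 is nearest to it and lies above it, and compound 1 lies furthest above it; both of these gaps are beyond the scatter. The two measured steps that reach compound 3 are a number 21.7 percentage points lower from compound 1 to compound 3 (beyond the scatter) and a number 19.4 percentage points lower from compound 2 to compound 3 (beyond the scatter), both modest and both beyond the scatter, whereas a number 2.3 percentage points lower from compound 1 to compound 2 (within the scatter) lies within the scatter.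

Compound 4, `O=C(N/N=C/c1ccc(F)cc1)c1cnccn1`, differs from compound 3 in one place: fluoro in place of trifluoromethyl on an aromatic carbon. Within the data shown here, no measured step exchanges trifluoromethyl for fluoro, so the two steps into compound 3 are the only ones that bear on it, and they only show that the trifluoromethyl compound sits beyond the scatter below both the unsubstituted and the isopropyl compound. Since fluoro is neither trifluoromethyl nor one of the two groups measured, the account therefore expects compound 4 to recover part of the lost inhibition in this assay, with a rise estimated as a number 12 percentage points higher from compound 3 to compound 4 (beyond the scatter). Compound 4 is accordingly estimated at 12%, with a range from 0% to 28%, leaving room for no rise at all.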

Compound 4, a percentage reported as inhibition, in the whole organism at one dose (the size of the read-out at that dose, not a potency): 24.5%
Compound 4: middle estimate off by 12.5 percentage points, on the low side; measured number inside the range.
By their numbers in this assay, from the lowest: compound 3; then compounds 2, 1 and 4 (each within the scatter of the next).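

In this assay, among these compounds, the exchange at this position, on an aromatic carbon para to a large group, gives a number 24.5 percentage points higher from compound 3 to compound 4 (beyond the scatter) and so separates fluoro clearly from trifluoromethyl, a comparison the earlier compounds could not make. Fluoro also stays level with the two other groups at this place: the steps of a number 2.8 percentage points higher from compound 1 to compound 4 (within the scatter) and a number 5.1 percentage points higher from compound 2 to compound 4 (within the scatter) show no difference that can be read, so among the four compounds shown hydrogen, isopropyl and fluoro cannot be told apart, and only trifluoromethyl stands off from the rest. The compounds come with no measurement that could account for this difference between trifluoromethyl and the other three groups.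

The compounds shown leave open whether other groups at this place, such as chloro, methoxy, an amine or a carboxylic acid, would stay level with hydrogen, isopropyl and fluoro or would drop to the level of trifluoromethyl. They also leave open whether the drop with trifluoromethyl is tied to this one position, since every substituent shown on the aromatic ring stands there.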